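Swapping the chain on a saturated-carbon oxygen: tolerance unchanged?

The compounds below may be only part of what the source reports. "The series", "measured", "known", "first", "only" and "open" are said of these compounds alone.

Compound 1 `CC(C)OC(=O)c1sc(N(COP(=O)(OC(C)(C)C)OC(C)(C)C)c2ncccn2)nc1-c1cnccn1` and compound 2 `COCCOCN(c1ncccn1)c1nc(-c2cnccn2)c(C(=O)OC(C)C)s1` share one core and differ only in the group hanging from an oxygen on a saturated carbon. In a toxicity assay on PH5CH cells (Homo sapiens) for cytotoxicity, read by MTT assay, with a stated time of 72 h (a lower number here means that less compound is tolerated, a higher number that more compound is tolerated), compound 1 gives 50000 nM. In this assay compound 2 gives 50000 nM. The step of no change at the digits printed from compound 1 to compound 2 (within the scatter) shows that trading the larger group for the short 2-methoxyethyl chain left the tolerated concentration where it was, so compound 2 stands level with compound 1. Compound 3 `CC(C)OC(=O)OCN(c1ncccn1)c1nc(-c2cnccn2)c(C(=O)OC(C)C)s1` carries the change (isopropoxycarbonyl in place of 2-methoxyethyl on an oxygen on a saturated carbon), that is, isopropoxycarbonyl in place of 2-methoxyethyl on an oxygen on a saturated carbon. Among the compounds with values here, only the step from compound 1 to compound 2 bears on this position, and it was flat. The expected step of no change at the digits printed from compound 2 to compound 3 (within the scatter) is therefore none beyond the scatter. Compound 3 is expected to give an estimated 50000 nM in this assay, within a range from 20000 nM to 100000 nM.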

Compound 3, half-maximal cytotoxic concentration: 50000 nM
For compound 3 middle estimate and measured number coincide at the digits printed; low and high end bracket the measured number.
By their numbers in this assay, from the lowest: compounds 1, 2 and 3 (each within the scatter of the next).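

In this assay the result is no change at the digits printed from compound 2 to compound 3 (within the scatter) and so this oxygen on a saturated carbon now carries isopropoxycarbonyl, a group with a double bond outside aromatic rings, without any readable shift from 2-methoxyethyl. Within the data shown here, the comparison with the larger, phosphorus-containing group reads no change at the digits printed from compound 1 to compound 3 (within the scatter) and extends the single flat step seen earlier to a second replacement. Three different groups at this one position therefore stand level in this cell assay.

From the compounds shown here alone, whether a group of another kind on this oxygen, such as an amine, a carboxylic acid or a longer alkyl chain, would also stay level remains open. No supporting evidence is available to explain why these three compounds stand level.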